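The source may hold more compounds than are shown below. What is called first, only, known or untested is meant among the compounds shown, and "the series" means these compounds.

Measured compounds:
compound 1 `N#CN/C(=N\CCOC(=O)c1ccccc1)NCCCOc1cccc(CN2CCCCC2)c1` with 7.64; compound 2 `N#CN/C(=N\CCNC(=O)c1ccc(N=[N+]=[N-])cc1)NCCCOc1cccc(CN2CCCCC2)c1` with 7.9; compound 3 `N#CN/C(=N\CCCNC(=O)c1ccc(N=[N+]=[N-])cc1)NCCCOc1cccc(CN2CCCCC2)c1` with 6.36.

In a functional assay on cardiac atrium for antagonist activity at histamine H2 receptor (Cavia porcellus) (a higher number here means a more potent compound, by a factor of ten per unit of this negative logarithm, a lower number a less potent compound), compound 3 gives the lowest of the three numbers. Compound 1 sits above it by a gap beyond the scatter, and compound 2 sits further above it, also beyond the scatter. Among the measured compounds shown here, compound 2 and compound 3 differ only in the chain between the double-bonded nitrogen and the amide; no step is tabulated for that pair, so only their two values speak, and they show the longer chain going with the markedly lower number.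

Compound 4 `N#CN/C(=N\CCCCNC(=O)c1ccccc1)NCCCOc1cccc(CN2CCCCC2)c1` is the next step: benzamidomethyl in place of ((4-azidophenyl)carbonyl)amino on a saturated chain carbon, three bonds along the chain from a double-bonded nitrogen. Of the measured steps, only a number 0.26 log units higher from compound 1 to compound 2 (within the scatter) touches the amide end of the chain, and it stayed within the scatter, which suggests that swapping the azide-bearing benzamide for a plain benzamide should matter little. The chain, however, grows by one more link, and the values of compound 2 and compound 3 show that lengthening this chain went with a large loss. Compound 4 is therefore expected to stay near compound 3 or fall somewhat further, giving an estimated a number 0.16 log units lower from compound 3 to compound 4 (within the scatter). The estimate for compound 4 in this assay is 6.2, with a range from 5.4 to 7.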

Compound 4, negative logarithm of the antagonist equilibrium constant: 6.81
Compound 4: middle estimate off by 0.61 log units, on the low side; the range from low to high includes it.
By their numbers in this assay, from the lowest: compound 3; then compound 4; then compounds 1 and 2 (each within the scatter of the next).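

In this assay, placing benzamidomethyl where ((4-azidophenyl)carbonyl)amino stood, on a saturated chain carbon three bonds along the chain from a double-bonded nitrogen, gives a number 0.45 log units higher from compound 3 to compound 4 (beyond the scatter), so the low value seen with the longer chain does not continue downward in this series. The shorter-chain compounds still hold a clear lead, with a number 1.09 log units lower from compound 2 to compound 4 (beyond the scatter) and a number 0.83 log units lower from compound 1 to compound 4 (beyond the scatter), which shows that the change at this end of the molecule can cost a large part of the value even when a benzamide is kept. No measurement shown here explains either the partial recovery or the remaining gap.

The step from compound 3 to compound 4 changes the chain and removes the azide together, so the compounds shown leave their separate contributions unresolved, and the azide on the chain of compound 4 or the plain benzamide on the chain of compound 3 would be needed to divide them. As far as these compounds go, how a longer chain than that of compound 4, or an amine in place of the amide, would read in this assay also remains open.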